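The source may report more compounds than this note shows. Statements on the series, on what has been measured and on what is new or still open speak of the compounds shown alone.

Compounds measured in a functional assay on MCF7 cells (Homo sapiens) for antiproliferative activity, read by MTT assay, with a stated time of 48 h; on this read-out lower numbers stand for stronger inhibition and higher numbers for weaker inhibition:
Compound 1 `COc1cccc(C(=O)Nc2cc3cnc(NCCN(C)C)cc3n(C)c2=O)c1`: 43300 nM
Compound 2 `CC(=O)Nc1cc2cnc(NCCN(C)C)cc2n(C)c1=O`: > 100000 nM
Compound 3 `CN(C)CCNc1cc2c(cn1)cc(NC(=O)c1ccccc1)c(=O)n2C`: 35100 nM

The entry for compound 2 of > 100000 nM is a limit of the assay and not a number. Compound 3, at 35100 nM, sits within the scatter of compound 1, at 43300 nM, so these two numeric values cannot be ordered. Compound 4 `CN(C)CCNc1cc2c(cn1)cc(NC(=O)c1ccncc1)c(=O)n2C` has pyridin-4-yl in place of phenyl on a carbonyl carbon. For the measured compounds named here, no measured step makes this exact exchange, so the nearest evidence is indirect. At the same carbonyl carbon, phenyl in place of methyl gave an at least 2.8-fold lower number from compound 2 to compound 3 (0.45 log units; beyond the scatter), which shows that this group can matter. Hydrogen in place of methoxy on the aromatic ring of compound 1 gave only a 1.2-fold lower number from compound 1 to compound 3 (0.09 log units; within the scatter). Since compound 4 keeps a six-membered aromatic ring at that carbon, no change beyond the scatter is expected in this assay. The estimated change is a 1.1-fold higher number from compound 3 to compound 4 (0.06 log units; within the scatter). For compound 4 the expected value is 40000 nM, with an estimated range of 17000 nM to 95000 nM.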

Compound 4, half-maximal inhibitory concentration: 36600 nM
Estimate against measurement, compound 4: 1.1-fold (0.04 log units) above, and the stated range covers the measured number.
By their numbers in this assay, from the lowest: compounds 3, 4 and 1 (each within the scatter of the next). At a limit, above all of these: compound 2.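

In this assay, putting pyridin-4-yl in place of phenyl on the carbonyl carbon brings in a ring nitrogen and one hydrogen-bond acceptor, yet the number does not move beyond the scatter: a 1.0-fold higher number from compound 3 to compound 4 (0.02 log units; within the scatter). The picture is the same against the 3-methoxyphenyl group, with a 1.2-fold lower number from compound 1 to compound 4 (0.07 log units; within the scatter), while the step from the methyl group reads an at least 2.7-fold lower number from compound 2 to compound 4 (0.43 log units; beyond the scatter), so pyridin-4-yl matches what phenyl showed over methyl at this carbon. The entry for compound 2 is a limit of the assay and not a number: the limit of > 100000 nM in this assay, at which 1 of the 4 values shown sits.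

The compounds shown leave open whether pyridin-3-yl or pyridin-2-yl would behave as pyridin-4-yl does. They also leave open whether a saturated ring such as piperidine, or an amine or a carboxylic acid on the aromatic ring, would take the number beyond the scatter of compound 3.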